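A Methyl Group Added to Compound 1

The source may hold more compounds than are shown below. What is called first, only, known or untested is meant among the compounds shown, and "the series" means these compounds.

For the measured compounds named here, in a functional assay on RS4-11 cells (Homo sapiens) for antiproliferative activity, read by MTT assay, with a stated time of 72 h (a lower number here means a stronger inhibitor, a higher number a weaker inhibitor), compound 1 (`C=C(Br)C(=O)Nc1ccc2c(c1)/C(=C/c1cccs1)C(=O)N2`) gives 12 nM, the lower of the two numbers so far, while compound 2 (`C=C(Br)C(=O)Nc1ccc2c(c1)/C(=C\c1cccs1)C(=O)N2`) gives 530 nM. That large step, a 44-fold higher number from compound 1 to compound 2 (1.65 log units; beyond the scatter), goes with the fact that compounds 1 and 2 differ only in the configuration as drawn. Compound 3 (`C=C(Br)C(=O)Nc1ccc2c(c1)/C(=C/c1sccc1C)C(=O)N2`) has methyl in place of hydrogen on an aromatic carbon, turning thiophen-2-yl into 3-methylthiophen-2-yl (methyl in place of hydrogen on an aromatic carbon). Going by the values given here, no measured step tests a methyl, but that large step shows the number can move far without any change of atoms. A modest rise is therefore expected in this assay, a 2.5-fold higher number from compound 1 to compound 3 (0.40 log units; beyond the scatter). For compound 3 the estimate is 30 nM, with a range of 7 nM to 150 nM.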

Compound 3, half-maximal inhibitory concentration: 0.4 nM
Estimate against measurement, compound 3: 75-fold (1.88 log units) above; the measured number lies below the stated range.
By their numbers in this assay, from the lowest: compound 3; then compound 1; then compound 2.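

In this assay, adding one methyl on an aromatic carbon, next to the ring atom that bears a large group, gives a 30-fold lower number from compound 1 to compound 3 (1.48 log units; beyond the scatter) in the direction of stronger inhibition. The earlier pair showed the number moving far with a change of configuration alone; this step shows that one added heavy atom at this position can also move it far, and downward. No fact at hand explains this gain.

As far as these compounds go, whether an ethyl, a methoxy or a chlorine at this position would do the same stays open. So does whether the methyl has this effect in the configuration drawn in compound 2.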